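The compounds below may be only part of what the source reports. "The series", "measured", "known", "first", "only" and "open" are said of these compounds alone.

Of the compounds shown here, three built on one shared core have been measured in a functional assay on HeLa cells (Homo sapiens) for inhibition, read by sulforhodamine B assay; on this read-out higher numbers stand for weaker inhibition and lower numbers for stronger inhibition. Compound 1 `O=C1C=C(Nc2ccc(I)cc2)C(=O)c2c1nc1n2[C@H]2OC[C@@H](O)[C@H]2OC1` gives 4070 nM, the lowest number shown, though its gap to compound 3 lies within the scatter. Compound 2 `CCOc1ccc(NC2=CC(=O)c3c(nc4n3[C@H]3OC[C@@H](O)[C@H]3OC4)C2=O)cc1` gives 14400 nM, and compound 3 `Cc1ccc(NC2=CC(=O)c3c(nc4n3[C@H]3OC[C@@H](O)[C@H]3OC4)C2=O)cc1` gives 6590 nM. Among the measured compounds shown here, the only single-point step, a 2.2-fold lower number from compound 2 to compound 3 (0.34 log units; beyond the scatter), concerns a substituent on an aromatic carbon. Compound 4 `O=C1C=C(NC2CCCCC2)C(=O)c2c1nc1n2[C@H]2OC[C@@H](O)[C@H]2OC1` differs from compound 1 in another way: cyclohexyl in place of 4-iodophenyl on an amine nitrogen. For the measured compounds named here, no measured step exchanges an aromatic ring for a non-aromatic ring, so the one step bears only loosely on this change, and the expectation rests mainly on the spread of the three values. Compound 4 is therefore expected to show a 2.2-fold higher number from compound 1 to compound 4 (0.34 log units; beyond the scatter), toward weaker inhibition. Compound 4 is estimated at 9000 nM in this assay, within 2500 nM to 35000 nM.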

Compound 4, half-maximal inhibitory concentration: > 16000 nM
Compound 4: only a limit was reported; the forecaster's own chance of this, stated with the estimate: 15%; middle value at least 1.7-fold (0.24 log units) from the limit.
By their numbers in this assay, from the lowest: compounds 1 and 3 (each within the scatter of the next); then compound 2. At a limit, above all of these: compound 4.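

At the amine nitrogen, replacing 4-iodophenyl with cyclohexyl gives an at least 3.9-fold higher number from compound 1 to compound 4 (0.59 log units; beyond the scatter), toward weaker inhibition. The earlier compounds shown here all carry a substituted phenyl ring at this place, so they showed changes only on that ring, whereas this step shows that this assay also responds when the aromatic ring itself gives way to a non-aromatic one. Compound 4 stands at a limit and not at a number: the limit of > 16000 nM in this assay, at which 1 of the 4 values shown sits.

From the compounds shown here alone, the true size of this step therefore remains open. Also open, going by these compounds, is whether an unsubstituted phenyl or a benzyl on this amine nitrogen would read closer to compound 1 or to compound 4.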